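A few compounds are considered here, and "the series" means these few. Any claim that something is new, unique, unknown or untested is made for them only; others in the source may bear on it.

In a functional assay on KYSE-450 cells (Homo sapiens) for inhibition, read by MTT assay, with a stated time of 48 h (on this read-out lower numbers stand for stronger inhibition and higher numbers for weaker inhibition), compound 1 (`COCC(=O)N(Cc1ccc(OC)c(O)c1)c1cc(OC)c(OC)c(OC)c1`) gives 460 nM and compound 2 (`COc1ccc(CN(C(C)=O)c2cc(OC)c(OC)c(OC)c2)cc1O`) gives 160 nM in these working notes. Compound 3 (`COc1ccc(CN(C(=O)C=C(C)C)c2cc(OC)c(OC)c(OC)c2)cc1O`) gives 280 nM and lies within the scatter of both. Compound 4 (`C/C=C/C=C/C(=O)N(Cc1ccc(OC)c(O)c1)c1cc(OC)c(OC)c(OC)c1`) carries penta-1,3-dien-1-yl in place of 2-methylprop-1-en-1-yl on a carbonyl carbon. Changes at this carbonyl carbon have so far moved the number little: two steps stay within the scatter (a 1.6-fold lower number from compound 1 to compound 3 (0.22 log units; within the scatter)) (a 1.8-fold higher number from compound 2 to compound 3 (0.24 log units; within the scatter)), and only one goes beyond it, modestly (a 2.9-fold lower number from compound 1 to compound 2 (0.46 log units; beyond the scatter)). No step beyond the scatter is therefore expected in this assay for this change, in either direction. The estimated step is small (a 1.1-fold higher number from compound 3 to compound 4 (0.03 log units; within the scatter)). Compound 4 is expected at 300 nM (estimated range 110 nM to 800 nM).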

Compound 4, half-maximal inhibitory concentration: 180 nM
Beside the measured number, compound 4's estimate is 1.7-fold (0.22 log units) above it, and the stated range covers the measured number.
By their numbers in this assay, from the lowest: compounds 2, 4, 3 and 1 (each within the scatter of the next, the first and the last beyond it).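

In this assay a second double bond and a longer chain on the carbonyl carbon leave the number unresolved from the earlier groups, with a 1.6-fold lower number from compound 3 to compound 4 (0.19 log units; within the scatter) and a 1.1-fold higher number from compound 2 to compound 4 (0.05 log units; within the scatter) both read as within the scatter. Methoxymethyl is the only group set apart from penta-1,3-dien-1-yl, with a 2.6-fold lower number from compound 1 to compound 4 (0.41 log units; beyond the scatter) as the one new step beyond the scatter. Nothing available accounts for these steps. Going by these compounds, whether an amine, a carboxylic acid or a longer saturated chain on this carbonyl carbon would keep the number in this range stays open.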